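The source may report more compounds than this note shows. Statements on the series, on what has been measured and on what is new or still open speak of the compounds shown alone.

Working notes on the series, all read in a functional assay on L1210 cells (Mus musculus) for antiproliferative activity, read by cell counting, with a stated time of 2 days (a higher number here means a weaker inhibitor, a lower number a stronger inhibitor), throughout. Among the compounds with values here, compound 1 `COc1cc(C(=O)c2sc(N)nc2N)cc(OC)c1OC` gives 48000 nM here, and compound 2 `COc1cc(C(=O)c2sc(N(C)C)nc2N)cc(OC)c1OC` gives 11000 nM as the lower of the two numbers so far. Within the data shown here, the only measured step is a 4.4-fold lower number from compound 1 to compound 2 (0.64 log units; beyond the scatter) on going from amino to dimethylamino, a modest move.

Next in line is compound 3 `CCN(CC)c1nc(N)c(C(=O)c2cc(OC)c(OC)c(OC)c2)s1`, which differs from compound 2 by diethylamino in place of dimethylamino on an aromatic carbon as the structural change. This is diethylamino in place of dimethylamino on an aromatic carbon, at the same place as the measured step. Among the measured compounds shown here, that single step is the only guide, and no measured compound carries a chain longer than those of dimethylamino, so nothing yet shows whether the downward direction continues.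

The expectation therefore starts from compound 2 at 11000 nM and takes the direction of a 4.4-fold lower number from compound 1 to compound 2 (0.64 log units; beyond the scatter) in a smaller size, since the change is smaller. The expected move is a 1.6-fold lower number from compound 2 to compound 3 (0.20 log units; within the scatter) as an estimate, and it may not clear the scatter. For compound 3 the estimated value is 7000 nM with an expected range from 2500 nM to 20000 nM in this assay terms.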

Compound 3, half-maximal inhibitory concentration: 62000 nM
Compound 3: the middle estimate sits 8.9-fold (0.95 log units) below what was measured, outside the stated range (above it).
By their numbers in this assay, from the lowest: compound 2; then compounds 1 and 3 (each within the scatter of the next).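

At the aromatic carbon next to the ring nitrogen and the ring sulfur, the response in this assay does not run in one direction along the series of amino substituents: a 4.4-fold lower number from compound 1 to compound 2 (0.64 log units; beyond the scatter) is followed by a 5.6-fold higher number from compound 2 to compound 3 (0.75 log units; beyond the scatter), so the longer ethyl chains undo the earlier move and more. Diethylamino and amino do not separate, with a 1.3-fold higher number from compound 1 to compound 3 (0.11 log units; within the scatter), which leaves dimethylamino as the only one of the three groups whose steps to both others lie beyond the scatter. Nothing at hand bears on why the direction turns between dimethylamino and diethylamino.

Open, from the compounds shown here alone, is where along this substituent the turn sets in: a methylamino or ethylamino group could fall with compound 2 or with compounds 1 and 3, and a ring amine such as pyrrolidine or morpholine, or a longer chain such as dipropylamino, could fall on either side as well. Also open, going by these compounds, is whether a change at the amino group two ring bonds away, on the same shared core, would alter this pattern in this assay.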